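The source may report more compounds than this note shows. Statements on the series, on what has been measured and on what is new or still open speak of the compounds shown alone.

Compound 1, `N/C(=N\NC(=S)N1CCCC1)c1ccccn1`, gives 6200 nM in a functional assay on HeLa cells (Homo sapiens) for cytotoxicity, read by MTT assay, with a stated time of 72 h; on this read-out lower numbers stand for stronger inhibition and higher numbers for weaker inhibition.
Compound 2, `Cc1ccnc(/C(N)=N/NC(=S)N2CCCCC2)c1`, gives 7700 nM in this assay.

Within the data shown here, compound 2 has the highest of the two numbers measured so far, but its only neighbour, compound 1, lies within the scatter of it, so the two cannot be told apart on this read-out; neither counts as stronger or weaker than the other. Compound 3, `Cc1ccnc(/C(N)=N/NC(=S)N2CCCC2)c1`, has not yet been tested. It is reached from compound 2 by one change: pyrrolidin-1-yl in place of piperidin-1-yl on a thiocarbonyl carbon. The same pyrrolidin-1-yl on the thiocarbonyl carbon is already present in compound 1, whose value in this assay sits close to that of compound 2, and compound 1 and compound 3 differ from each other only in the shared core. Among the measured compounds shown here, no step between measured compounds isolates the ring change, so the expectation rests on the closeness of compound 1 and compound 2 alone. The step from compound 2 to compound 3 is expected to be a 1.2-fold lower number from compound 2 to compound 3 (0.07 log units; within the scatter), that is, no change beyond the scatter in either direction. Compound 3 is therefore estimated at 6500 nM, with a likely range from 2500 nM to 16000 nM.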

Compound 3, half-maximal inhibitory concentration: 1900 nM
Estimate against measurement, compound 3: 3.4-fold (0.53 log units) above; the whole stated range lies above it.
By their numbers in this assay, from the lowest: compound 3; then compounds 1 and 2 (each within the scatter of the next).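

Two single changes can now be read on their own, which the earlier pair of compounds could not offer. With the methyl kept, pyrrolidin-1-yl in place of piperidin-1-yl on the thiocarbonyl carbon gives a 4.1-fold lower number from compound 2 to compound 3 (0.61 log units; beyond the scatter) in this assay and shows that a five-membered ring in place of a six-membered ring at this position can move the number beyond the scatter. With pyrrolidin-1-yl kept, methyl in place of hydrogen on an aromatic carbon gives a 3.3-fold lower number from compound 1 to compound 3 (0.51 log units; beyond the scatter), so the methyl also counts when this ring is present, and nothing at hand explains either step.

The compounds shown leave open whether the trend continues with other groups on the thiocarbonyl carbon, such as azetidin-1-yl, morpholin-4-yl or an open-chain dimethylamino group. They also leave open whether ethyl, methoxy or chlorine could take the place of the methyl on the aromatic carbon, and whether the pyrrolidin-1-yl and methyl steps would keep their size with any of these groups present.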